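A Nitrophenyl Ester Against a Limit Reading

A few compounds are considered here, and "the series" means these few. Any claim that something is new, unique, unknown or untested is made for them only; others in the source may bear on it.

- Compound 1 `CC1=CC[C@H]2[C@H](CC[C@]2(C)O)C(C)(C)[C@@H]1CC[C@H]1[C@]2(C)CC[C@H](OC(=O)c3ccc(Cl)cc3)C(C)(C)O[C@H]2CC[C@@]1(C)O` gives 24100 nM
- Compound 2 `CC1=CC[C@H]2[C@H](CC[C@]2(C)O)C(C)(C)[C@@H]1CC[C@H]1[C@]2(C)CC[C@H](OC(=O)NCc3ccccc3)C(C)(C)O[C@H]2CC[C@@]1(C)O` gives 24500 nM
- Compound 3 `CC1=CC[C@H]2[C@H](CC[C@]2(C)O)C(C)(C)[C@@H]1CC[C@H]1[C@]2(C)CC[C@H](OC(=O)NS(=O)(=O)c3ccc(C)cc3)C(C)(C)O[C@H]2CC[C@@]1(C)O` gives > 50000 nM as a limit

In a functional assay on MCF7 cells (Homo sapiens) for antiproliferative activity, read by MTT assay, with a stated time of 72 h (a lower number here means a stronger inhibitor, a higher number a weaker inhibitor), compound 3 has no number, only the limit > 50000 nM that the assay reports for it. The next compound, compound 4 `CC1=CC[C@H]2[C@H](CC[C@]2(C)O)C(C)(C)[C@@H]1CC[C@H]1[C@]2(C)CC[C@H](OC(=O)c3ccc([N+](=O)[O-])cc3)C(C)(C)O[C@H]2CC[C@@]1(C)O`, differs from it by 4-nitrophenyl in place of ((4-methylphenyl)sulfonyl)amino on a carbonyl carbon in one place: 4-nitrophenyl in place of ((4-methylphenyl)sulfonyl)amino on a carbonyl carbon.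

Within the data shown here, three measured steps concern this same place. The step of a 1.0-fold higher number from compound 1 to compound 2 (0.01 log units; within the scatter) shows that benzylamino and 4-chlorophenyl there give values within the scatter of each other. Among the measured compounds shown here, the step of an at least 2.0-fold higher number from compound 1 to compound 3 (0.31 log units; beyond the scatter) is the one that introduced the group now leaving, and it is modest. The step of an at least 2.0-fold higher number from compound 2 to compound 3 (0.30 log units; that floor lies within the scatter) has a floor that does not clear the scatter, so it adds little.

Compound 4 again carries a substituted phenyl directly on the carbonyl carbon, as does compound 1 at 24100 nM in this assay, and that value is the main basis for the expectation here. A modest step to a lower number is therefore expected, roughly reversing the one measured on entry of the sulfonylamino group. The expected step is an at least 2.0-fold lower number from compound 3 to compound 4 (0.30 log units; that floor lies within the scatter) in this assay, though it could remain small. The estimate for compound 4 is 25000 nM, with an expected range from 12000 nM to 50000 nM.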

Compound 4, half-maximal inhibitory concentration: 21600 nM
Beside the measured number, compound 4's estimate is 1.2-fold (0.06 log units) above it, and the stated range covers the measured number.
By their numbers in this assay, from the lowest: compounds 4, 1 and 2 (each within the scatter of the next). At a limit, above all of these: compound 3.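

The change from ((4-methylphenyl)sulfonyl)amino to 4-nitrophenyl on this carbonyl carbon gives an at least 2.3-fold lower number from compound 3 to compound 4 (0.36 log units; beyond the scatter) in this assay, so a second group, after 4-chlorophenyl, now stands clear of compound 3 by more than the scatter. Nitro in place of chloro on the aromatic carbon gives a 1.1-fold lower number from compound 1 to compound 4 (0.05 log units; within the scatter), and 4-nitrophenyl in place of benzylamino gives a 1.1-fold lower number from compound 2 to compound 4 (0.05 log units; within the scatter), so the three groups with a measured number at this position cannot be told apart in this assay. Only the ((4-methylphenyl)sulfonyl)amino group of compound 3 stands apart, and its reading is a limit, not a number: the limit of > 50000 nM in this assay, at which 1 of the 4 values shown sits.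

As far as these compounds go, how far compound 3 actually lies from the other three stays unknown, so the steps to it give only a floor. From the compounds shown here alone, it also remains open whether a free hydroxyl, an unsubstituted phenyl or a longer alkyl chain on this oxygen or carbonyl carbon would move the number beyond the scatter, or whether the number depends on the shared core rather than on this position.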